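Changing the Ring on the Ketone of a Shared Core

The compounds below may be only part of what the source reports. "The series", "measured", "known", "first", "only" and "open" are said of these compounds alone.

Of the compounds shown here, two built on the same core have been tested in a functional assay on CHO-K1 cells for antagonist activity at adenosine receptor A2b (Homo sapiens), read by FLIPR and calcium flux; a lower number here means a stronger inhibitor, a higher number a weaker inhibitor. Compound 1 `Cc1ccc(C(=O)c2nc(NC(=O)c3cccnc3)nc3ccsc23)s1` gives 287 nM in this assay. Compound 2 `O=C(c1nccs1)c1nc(NCc2cccnc2)nc2ccsc12` gives 176 nM in this assay. Compound 2 has the lowest of the two numbers shown, and compound 1 the higher one, but the gap between them lies within the usual scatter of this kind of measurement, so the two cannot be separated on these data.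

Compound 3 `O=C(c1ccncc1)c1nc(NCc2cccnc2)nc2ccsc12` has not yet been measured. It differs from compound 2 in one place: pyridin-4-yl in place of 1,3-thiazol-2-yl on a carbonyl carbon. The rest of the molecule is untouched. Among the compounds with values here, no measured pair in this set carries such a change, so nothing about its size or direction can be read from the numbers at hand. With only the shared core and a single ring exchange to go on, compound 3 is expected to land close to compound 2, with a step no larger than the scatter and no clear direction. The estimate for compound 3 in this assay is 250 nM, with a range from 90 nM to 700 nM. The expected step from compound 2 to compound 3 is a 1.4-fold higher number from compound 2 to compound 3 (0.15 log units; within the scatter).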

Compound 3, half-maximal inhibitory concentration: 869 nM
Estimate against measurement, compound 3: 3.5-fold (0.54 log units) below, outside the stated range (above it).
By their numbers in this assay, from the lowest: compounds 2 and 1 (each within the scatter of the next); then compound 3.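

The exchange of 1,3-thiazol-2-yl for pyridin-4-yl on a carbonyl carbon gives in this assay a clear result: a 4.9-fold higher number from compound 2 to compound 3 (0.69 log units; beyond the scatter) is a step that goes beyond the usual scatter, and the direction is toward a weaker inhibitor. Within the data shown here, this is the first pair here that differs in one place only, and it shows that the ring on this carbonyl carbon is not a free choice: with the rest of the molecule unchanged, this single exchange alone is enough to move the result measurably. Nothing measured here accounts for the step, so the data record its size and direction but offer no explanation for it.

One pair cannot tell whether the loss belongs to pyridin-4-yl in particular or whether other six-membered rings on the carbonyl carbon would behave the same way, and a plain phenyl ring at this place would help to separate the two. Going by these compounds, it also remains open whether a small open chain such as ethyl could stand in for a ring here, and whether the same exchange would give a similar step on the core of compound 1.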